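Pyridin-2-yl in place of phenyl: working notes

The source may hold more compounds than are shown below. What is called first, only, known or untested is meant among the compounds shown, and "the series" means these compounds.

In a functional assay on C-33-A cells (Homo sapiens) for antiproliferative activity, read by MTT assay (on this read-out higher numbers stand for weaker inhibition and lower numbers for stronger inhibition), compound 1 `c1ccc(N2CCN(c3nc(-n4ccc5ccccc54)c4ccccc4n3)CC2)cc1` gives 50 ug/mL and stands level with compound 2 `c1ccc2c(c1)ccn2-c1nc(N2CCCCC2)nc2ccccc12` which gives 50 ug/mL at the digits shown, within the usual scatter. Among the measured compounds shown here, no pair of measured compounds differs in one place only, so no single change in this small set has a measured size.

Compound 3 `c1ccc(N2CCN(c3nc(-n4ccc5ccccc54)c4ccccc4n3)CC2)nc1` carries pyridin-2-yl in place of phenyl on an amine nitrogen in a ring and nothing else in compound 1 changes. For the measured compounds named here, with no measured precedent for this change, its direction cannot be read from the data, and no step beyond the scatter is expected in this assay on this evidence. The estimated step is small and is expected as a 1.1-fold lower number from compound 1 to compound 3 (0.05 log units; within the scatter) with no firm direction. That expectation rests on compound 1 at 50 ug/mL as the closest measured reference. In this assay the expected value for compound 3 is 45 ug/mL with an estimated range from 20 ug/mL to 100 ug/mL in repeat measurements.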

Compound 3, half-maximal inhibitory concentration: 50 ug/mL
Compound 3: middle estimate off by 1.1-fold (0.05 log units), on the low side; measured number inside the range.
By their numbers in this assay, from the lowest: compounds 1, 2 and 3 (each within the scatter of the next).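

Within this assay, pyridin-2-yl in place of phenyl on an amine nitrogen in a ring gives no change at the digits printed from compound 1 to compound 3 (within the scatter) and is the only single change here with a measured size. The exchange puts a ring nitrogen and a hydrogen-bond acceptor at this position, and with this pair that acceptor does not separate the two compounds on this read-out. No measured property of either compound bears on this result, so it stands as an observation without an explanation.

This single pair speaks only for this position on the core of compound 1, and it leaves open whether a pyridin-3-yl or pyridin-4-yl ring, with the nitrogen placed elsewhere, would read the same way. Also open, from the compounds shown here alone, is whether a benzyl group, an acetyl group or a chain ending in a carboxylic acid on the same amine nitrogen would move the number in this assay beyond the scatter, and so whether this position responds to any change at all.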